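The compounds below may be only part of what the source reports. "The series", "measured", "known", "first", "only" and "open" are said of these compounds alone.

In an assay on CHO cells for displacement of a labelled ligand from adenosine receptor A1 (Homo sapiens), read by scintillation counting, with a stated time of 1 h, tested at 1 uM (a lower number here means less inhibition, a higher number more inhibition at the concentration tested (going by the name of the read-out)), the three measured compounds stand as follows. Compound 1 `Clc1cccc(-c2cnc(NC3CCCC3)nc2-c2ccccc2)c1` gives > 80%, which is a limit of the assay. Compound 2 `CCCCNc1ncc(-c2cccc(Cl)c2)c(-c2ccccc2)n1` gives 56%. Compound 3 `OCCCCNc1ncc(-c2cccc(Cl)c2)c(-c2ccccc2)n1` gives > 80%, again a limit of the assay.

Compound 3 thus sits at the limit of > 80% in this assay, at which 2 of the 3 values shown sit, and only a limit is known for it, so a step that the two limits leave unreadable from compound 1 to compound 3 cannot be sized. Compound 4 `CN(C)CCNc1ncc(-c2cccc(Cl)c2)c(-c2ccccc2)n1` differs from compound 3 by dimethylamino in place of 2-hydroxyethyl on a saturated chain carbon, two bonds along the chain from a nitrogen on an aromatic ring. Within the data shown here, the step that bears on this is a number at least 24 percentage points higher from compound 2 to compound 3 (beyond the scatter), where the hydroxy entered; here it leaves, while dimethylamino enters, for which no measured step exists. Also a number at least 24 percentage points lower from compound 1 to compound 2 (beyond the scatter) shows how far a chain compound can lie under the limit. The expected step is therefore a number at least 15 percentage points lower from compound 3 to compound 4 (beyond the scatter), downward but uncertain. Compound 4 is estimated at 65%, between 35% and 88%.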

Compound 4, a percentage reported as inhibition, at one concentration (the size of the read-out at that concentration, not a potency): 52%
For compound 4 the middle estimate is 13 percentage points above the measured one; the range from low to high includes it.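

In this assay, the end of the chain clearly matters at this position: dimethylamino does not match the hydroxy end, with a number at least 28 percentage points lower from compound 3 to compound 4 (beyond the scatter), and the ring-bearing cyclopentyl compound gives a number at least 28 percentage points lower from compound 1 to compound 4 (beyond the scatter). Dimethylamino in place of ethyl gives a number 4 percentage points lower from compound 2 to compound 4 (within the scatter), so these two chains cannot be told apart here. Both larger steps start from a limit of the assay: the limit of > 80% in this assay, at which 2 of the 4 values shown sit.

Going by these compounds, how a primary amine or a carboxylic acid at the chain end would read stays open. So does the effect of dimethylamino on a longer chain.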